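A few compounds are considered here, and "the series" means these few. Any claim that something is new, unique, unknown or untested is made for them only; others in the source may bear on it.

The measured compounds:

compound 1, `O=C(/C=C/c1ccc(OCCCCCO[N+](=O)[O-])c(O)c1)OCCCCCO[N+](=O)[O-]` — 5730 nM
compound 2, `O=C(/C=C/c1ccc(OCCCCCCO[N+](=O)[O-])c(O)c1)OCCCCCCO[N+](=O)[O-]` — 1350 nM
compound 3, `COc1cc(/C=C/C(=O)OCCCCCO[N+](=O)[O-])ccc1OCCCCCO[N+](=O)[O-]` — > 50000 nM

In a functional assay on HeLa cells (Homo sapiens) for cytotoxicity, read by resazurin assay, with a stated time of 72 h (on this read-out higher numbers stand for weaker inhibition and lower numbers for stronger inhibition), compound 1 gives 5730 nM and compound 2 gives 1350 nM. For compound 3 the value is only a limit, > 50000 nM, so the number itself is not known. Compound 1 and compound 3 differ in one place: methyl in place of hydrogen on an oxygen on an aromatic ring. That change made a step of an at least 8.7-fold higher number from compound 1 to compound 3 (0.94 log units; beyond the scatter), a result that rests on (the limit of > 50000 nM in this assay, at which 1 of the 3 values shown sits). How the core of compound 1 and the core of compound 2 differ is not broken down here. The unmeasured compound 4, `COc1cc(/C=C/C(=O)OCCCCCCO[N+](=O)[O-])ccc1OCCCCCCO[N+](=O)[O-]`, differs from compound 2 in the same kind of change: methyl in place of hydrogen on an oxygen on an aromatic ring. For the measured compounds named here, since compound 2 is the lowest of the measured numbers, the step from compound 1 to compound 3 is the only guide to what this change does. Compound 4 is therefore expected to give a weaker result than compound 2, with an expected step of an 11-fold higher number from compound 2 to compound 4 (1.05 log units; beyond the scatter). The estimate for compound 4 is 15000 nM, between 4000 nM and 50000 nM.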

Compound 4, half-maximal inhibitory concentration: > 50000 nM
Compound 4: only a limit was reported; the forecaster's own chance of this, stated with the estimate: 30%; middle value at least 3.3-fold (0.52 log units) away from the limit.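

In this assay, the change from hydroxy to methoxy on the core of compound 2 gives an at least 37-fold higher number from compound 2 to compound 4 (1.56 log units; beyond the scatter), so weaker inhibition follows this change on both cores shown, and the direction carries over from one to the other. Compound 4 gives > 50000 nM, which is a limit and not a number, and compound 3 stands at the same limit: the limit of > 50000 nM in this assay, at which 2 of the 4 values shown sit. Two cores show that the direction of the change is shared, but they do not show how large the change really is on either one, or whether its size depends on the core: the same change on two cores in this assay, an at least 8.7-fold higher number (0.94 log units; beyond the scatter) from compound 1 to compound 3 and an at least 37-fold higher number (1.56 log units; beyond the scatter) from compound 2 to compound 4; the limit leaves it open whether they differ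

The compounds shown leave open whether another group on that oxygen, such as ethoxy or acetyl, would be tolerated any better than methyl, or whether only the hydroxy form keeps the inhibition. They also leave open what a longer chain would do on the cores that carry the hydroxy group.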